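Swapping the aryl group on the ring nitrogen

The source may report more compounds than this note shows. Statements on the series, on what has been measured and on what is new or still open speak of the compounds shown alone.

Of the compounds shown here, three sharing one core have been measured in a functional assay on HT-29 cells (Homo sapiens) for antiproliferative activity, read by MTT assay, with a stated time of 72 h; on this read-out lower numbers stand for stronger inhibition and higher numbers for weaker inhibition. Compound 1 `CNC(=O)c1cc(Oc2ccc(NC(=O)c3cc4cccnc4n(-c4ccc(Cl)cc4)c3=O)cc2)ccn1` gives 390 nM. Compound 2 `CCNC(=O)c1cc(Oc2ccc(NC(=O)c3cc4cccnc4n(-c4ccccc4)c3=O)cc2)ccn1` gives 220 nM, and compound 3 `CCNC(=O)c1cc(Oc2ccc(NC(=O)c3cc4cccnc4n(-c4ccccc4F)c3=O)cc2)ccn1` gives 260 nM. Compound 3 stands second highest of the three numbers; its nearest neighbour is compound 2 and its furthest is compound 1, and both of those gaps fall within the usual scatter. Among the compounds with values here, the only step between measured compounds that differ in one place is a 1.2-fold higher number from compound 2 to compound 3 (0.07 log units; within the scatter), which leaves the read-out essentially where it was.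

Compound 4 `CCNC(=O)c1cc(Oc2ccc(NC(=O)c3cc4cccnc4n(-c4ccc(Cl)cc4)c3=O)cc2)ccn1` has not yet been measured. It differs from compound 3 as follows: 4-chlorophenyl in place of 2-fluorophenyl on an aromatic nitrogen. Within the data shown here, no measured step covers this exact exchange. The step of a 1.2-fold higher number from compound 2 to compound 3 (0.07 log units; within the scatter) shows that fluoro in place of hydrogen on the ring attached to the nitrogen changes little. Compound 1, which carries the 4-chlorophenyl that enters here, gives 390 nM, while compound 2 with an unsubstituted phenyl gives 220 nM; these two also differ elsewhere, so only their values can be set side by side, and they sit within the scatter of each other. The step of a 1.2-fold higher number from compound 3 to compound 4 (0.06 log units; within the scatter) is therefore expected to be small, not beyond the scatter. Compound 4 is estimated at 300 nM, with a range from 150 nM to 600 nM.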

Compound 4, half-maximal inhibitory concentration: 330 nM
For compound 4 the middle estimate is 1.1-fold (0.04 log units) below the measured one, and the stated range covers the measured number.
By their numbers in this assay, from the lowest: compounds 2, 3, 4 and 1 (each within the scatter of the next).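

In this assay, within the data shown here, the direct exchange on the aromatic nitrogen gives a 1.3-fold higher number from compound 3 to compound 4 (0.10 log units; within the scatter) and adding the chloro to the unsubstituted phenyl gives a 1.5-fold higher number from compound 2 to compound 4 (0.18 log units; within the scatter); these are the first steps at this position to involve a chlorine-bearing ring, and both stay within the scatter. Among these compounds, the new compound also supplies the first one-place comparison at the other end of the molecule, where, with 4-chlorophenyl held fixed, methyl in place of hydrogen on a saturated chain carbon bound to an amide-type nitrogen gives a 1.2-fold lower number from compound 1 to compound 4 (0.07 log units; within the scatter) and likewise stays within the scatter. With the ethyl amide held fixed, phenyl, 2-fluorophenyl and 4-chlorophenyl on the aromatic nitrogen therefore cannot be told apart in this read-out, and no supporting measurement is available to account for that.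

All the groups shown on the nitrogen are phenyl rings, bare or carrying one halogen, so it remains open how the read-out would respond to an amine or a carboxylic acid on that ring, or to a cyclohexyl group in its place. As far as these compounds go, it also remains open whether a longer chain on the amide, such as butyl, would stay within the scatter.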